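Removing the benzylsulfanyl group on the second dichloro core

The source may hold more compounds than are shown below. What is called first, only, known or untested is meant among the compounds shown, and "the series" means these compounds.

Compound 1 `OCCOCn1c(SCc2ccccc2)nc2cc(Cl)c(Cl)cc21` is the reference point of the set. In a functional assay on KB cells (Homo sapiens) for inhibition (a higher number here means a weaker inhibitor, a lower number a stronger inhibitor), compound 1 gives 55000 nM. Compound 2 `OCCOCn1cnc2cc(Cl)c(Cl)cc21` differs from it only by hydrogen in place of benzylsulfanyl on an aromatic carbon. For compound 2 in this assay the result is a limit of the assay, > 100000 nM. That gives an at least 1.8-fold higher number from compound 1 to compound 2 (0.25 log units; that floor lies within the scatter), a floor rather than a number because the limit of > 100000 nM in this assay, at which 2 of the 3 values shown sit, is where compound 2 sits.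

Compound 3 `OCCOCn1c(SCc2ccccc2)nc2c(Cl)cc(Cl)cc21` has the same atoms as compound 1, joined differently; the difference between the two cores is not broken down here. For compound 3 in this assay only a limit is recorded, > 100000 nM.

Compound 4 `OCCOCn1cnc2c(Cl)cc(Cl)cc21` stands to compound 3 as compound 2 stands to compound 1: hydrogen in place of benzylsulfanyl on an aromatic carbon. The place is the same word for word, so this is the same change. The step that the limit leaves unreadable from compound 3 to compound 4 is expected to look like an at least 1.8-fold higher number from compound 1 to compound 2 (0.25 log units; that floor lies within the scatter) in direction, because compound 3 already rests on the limit of > 100000 nM in this assay, at which 2 of the 3 values shown sit, before the group leaves. Compound 4 is therefore expected to give 200000 nM in this assay, within an estimated range of 100000 nM to 600000 nM, most probably reported as a limit only.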

Compound 4, half-maximal inhibitory concentration: > 100000 nM
Compound 4 ended at the assay's limit; the forecaster's own chance of this, stated with the estimate: 90%; the middle value is on the limit's open side.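

Compound 3 and compound 4 both rest on a limit in this assay, so no step can be read between them: the limit of > 100000 nM in this assay, at which 3 of the 4 values shown sit.

The compounds shown leave open how large the change on removing benzylsulfanyl is on the core of compound 3, and whether it matches the change seen on the core of compound 1.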